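Amine substituent exchange: compound 2 to compound 3

The compounds below may be only part of what the source reports. "The series", "measured", "known", "first", "only" and "open" are said of these compounds alone.

Of the compounds shown here, two have been measured in an assay on CHO cells for displacement of a labelled ligand from 5-hydroxytryptamine receptor 1D (Homo sapiens); on this read-out lower numbers stand for stronger inhibition and higher numbers for weaker inhibition. Compound 1 `O[C@H]1Cc2ccccc2C1NC1CCN(CCCc2c[nH]c3ccc(-n4cnnc4)cc23)CC1` gives 37 nM and compound 2 `CC(=O)Nc1ccc(CNC2CCN(CCCc3c[nH]c4ccc(-n5cnnc5)cc34)CC2)cc1` gives 3 nM. Among the compounds with values here, the single measured step, a 12-fold lower number from compound 1 to compound 2 (1.09 log units; beyond the scatter), leaves compound 2 with the lower of the two numbers, and its gap to compound 1 is beyond the scatter.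

Compound 3 `C[C@@H](NC1CCN(CCCc2c[nH]c3ccc(-n4cnnc4)cc23)CC1)c1ccccc1` has not been measured. It differs from compound 2 in one place: 1-phenylethyl in place of 4-acetamidobenzyl on an amine nitrogen. Within the data shown here, no measured step covers this exchange. Among the measured compounds shown here, the only step recorded, a 12-fold lower number from compound 1 to compound 2 (1.09 log units; beyond the scatter), sits on the same amine nitrogen and shows that changing the group there can move this assay by a large amount, but it gives no direction for the present exchange. The group that enters has fewer heavy atoms and no hydrogen-bond donor or acceptor, as the count shows, and compound 2 already holds the lowest number. A moderate step back toward a higher number is expected, a 5.0-fold higher number from compound 2 to compound 3 (0.70 log units; beyond the scatter). Compound 3 is estimated at 15 nM, with a range from 4 nM to 60 nM.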

Compound 3, half-maximal inhibitory concentration: 0.4 nM
Compound 3: middle estimate off by 38-fold (1.57 log units), on the high side, outside the stated range (below it).
By their numbers in this assay, from the lowest: compound 3; then compound 2; then compound 1.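

In this assay the exchange at the amine nitrogen gives a 7.5-fold lower number from compound 2 to compound 3 (0.88 log units; beyond the scatter) and shows that the hydrogen-bond donor and acceptor of 4-acetamidobenzyl are not needed for a low number here: 1-phenylethyl, with 8 heavy atoms and 0 hydrogen-bond donors or acceptors, goes lower still. The wider comparison gives a 93-fold lower number from compound 1 to compound 3 (1.97 log units; beyond the scatter) and extends the range seen at this nitrogen, with compound 3 lowest of the three and its steps to compound 1 and compound 2 both beyond the scatter. Nothing in the data accounts for either step.

Within the data shown here, with only three groups compared at this nitrogen, it remains open what the defined stereocentre of 1-phenylethyl contributes, since a plain benzyl group and the opposite configuration of 1-phenylethyl would be needed to separate the methyl group and its orientation from the aromatic ring itself. Also open, on these data alone, is how this assay would respond to a 1-phenylethyl group that also carries an acetamido group, or to a carboxylic acid or a longer chain in the same place.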